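A chloropyridine replaces pyridine on the amide nitrogen

The source may hold more compounds than are shown below. What is called first, only, known or untested is meant among the compounds shown, and "the series" means these compounds.

Compound 1 `COc1ccc(C(=O)Nc2c(F)cccc2F)cc1OC1CCCC1` gives 70 nM in an assay on isolated protein for inhibition of phosphodiesterase 4A (Sus scrofa); a lower number here means a stronger inhibitor, a higher number a weaker inhibitor.
Compound 2 `COc1ccc(C(=O)Nc2ccccc2SC)cc1OC1CCCC1` gives 1200 nM in this assay.
Compound 3 `COc1ccc(C(=O)Nc2ccccn2)cc1OC1CCCC1` gives 1000 nM in this assay.

Compound 3 stands second highest of the three numbers. Its nearest neighbour is compound 2, with a 1.2-fold lower number from compound 2 to compound 3 (0.08 log units; within the scatter), so the two are indistinguishable. Compound 1 is far off: a 14-fold higher number from compound 1 to compound 3 (1.15 log units; beyond the scatter), and likewise a 17-fold higher number from compound 1 to compound 2 (1.23 log units; beyond the scatter). Both large steps came from exchanging the ring on the amide nitrogen, so that position clearly matters in this assay.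

Compound 4 `COc1ccc(C(=O)Nc2ccncc2Cl)cc1OC1CCCC1` differs from compound 3 by 3-chloropyridin-4-yl in place of pyridin-2-yl on an amide-type nitrogen. Since ring exchanges here have moved the number a lot, and the only halogen-bearing ring, in compound 1, gave the lowest number, a lower number is expected for compound 4: a 5.0-fold lower number from compound 3 to compound 4 (0.70 log units; beyond the scatter). The estimate for compound 4 is 200 nM, within 50 nM to 800 nM.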

Compound 4, half-maximal inhibitory concentration: 16 nM
The estimate for compound 4 lay 13-fold (1.10 log units) above the measured number; the measured number lies below the stated range.
By their numbers in this assay, from the lowest: compound 4; then compound 1; then compounds 3 and 2 (each within the scatter of the next).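

In this assay, among the compounds shown here, the ring on the amide nitrogen proves able to give far lower numbers than the earlier compounds showed, with a 63-fold lower number from compound 3 to compound 4 (1.80 log units; beyond the scatter) and a 75-fold lower number from compound 2 to compound 4 (1.88 log units; beyond the scatter) for 3-chloropyridin-4-yl. The step of a 4.4-fold lower number from compound 1 to compound 4 (0.64 log units; beyond the scatter) puts this ring past 2,6-difluorophenyl as well, so a pyridine ring on this nitrogen can carry the lowest number of the four.

As far as these compounds go, compound 4 differs from compound 3 both in the chlorine and in where the ring is attached, so the share of each stays unknown, as does whether bromine or a methyl group could stand in for the chlorine. Nothing measured here explains the drop.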